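The source may hold more compounds than are shown below. What is called first, only, known or untested is meant among the compounds shown, and "the series" means these compounds.

Measured in a functional assay on the whole organism with Mus musculus as the target, in the maximal electroshock model, with a stated time of 0.5 h; a higher number here means that more compound is needed for the effect, a lower number that less compound is needed:

Compound 1 `SC1=NC(n2nc(-c3ccccc3)nc2-c2ccccc2)=CC(c2ccc(Br)cc2)N1` gives 100 mg/kg.
Compound 2 `Oc1ccc(C2C=C(n3nc(-c4ccccc4)nc3-c3ccccc3)N=C(S)N2)cc1` gives 30 mg/kg.

Among the compounds with values here, compound 2 has the lowest of the two numbers, so less of it is needed; the only step, a 3.3-fold lower number from compound 1 to compound 2 (0.52 log units; beyond the scatter), separates it from compound 1. Compound 3 `COc1ccc(C2C=C(n3nc(-c4ccccc4)nc3-c3ccccc3)N=C(S)N2)c(OC)c1` differs from compound 2 by 2,4-dimethoxyphenyl in place of 4-hydroxyphenyl on a saturated ring carbon. Within the data shown here, no measured step swaps a hydroxy for methoxy groups, so the one step gives only loose guidance. Because the step of a 3.3-fold lower number from compound 1 to compound 2 (0.52 log units; beyond the scatter) came with the hydroxy entering, its loss is expected to move the number back up moderately, a 1.7-fold higher number from compound 2 to compound 3 (0.22 log units; within the scatter). Compound 3 is thus estimated at 50 mg/kg, within 20 mg/kg to 150 mg/kg.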

Compound 3, minimum effective dose: 30 mg/kg
Compound 3: the middle estimate sits 1.7-fold (0.22 log units) above what was measured, within the range that was stated.
By their numbers in this assay, from the lowest: compounds 2 and 3 (each within the scatter of the next); then compound 1.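

In this assay, the step of no change at the digits printed from compound 2 to compound 3 (within the scatter) shows that this saturated ring carbon accepts 2,4-dimethoxyphenyl in place of 4-hydroxyphenyl, so a hydrogen-bond donor on this aromatic ring is not required to keep the number at this level. The step of a 3.3-fold lower number from compound 1 to compound 3 (0.52 log units; beyond the scatter) shows that the lower number relative to 4-bromophenyl is not confined to the hydroxy compound. No available evidence explains this result. From the compounds shown here alone, whether a single methoxy group would serve equally remains open, as does the effect of an amine or a carboxylic acid on this aromatic ring.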